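Replacing the imidazole phenyl with a neohexyl chain

A few compounds are considered here, and "the series" means these few. Any claim that something is new, unique, unknown or untested is made for them only; others in the source may bear on it.

Three compounds with the shared core of compound 1 `O=C(O)c1ccccc1-c1ccc(CCc2ncc(Cc3cccc(F)c3)[nH]2)cc1` were tested in an in vitro functional assay on cells for agonist activity at Bombesin receptor subtype-3 (Mus musculus), read by luminescence and calcium flux; a lower number here means that less compound is needed, a higher number that more compound is needed for the effect. Compound 1 gives 7.9 nM. Compound 2 `O=C(O)c1ccccc1-c1ccc(CCc2ncc(Cc3ccc(F)cc3)[nH]2)cc1` gives 50 nM, a step of a 6.3-fold higher number from compound 1 to compound 2 (0.80 log units; beyond the scatter). Compound 3 `O=C(O)c1ccccc1-c1ccc(CCc2ncc(-c3ccccc3)[nH]2)cc1` gives 872 nM and stands highest of the three, its steps being a 110-fold higher number from compound 1 to compound 3 (2.04 log units; beyond the scatter) and a 17-fold higher number from compound 2 to compound 3 (1.24 log units; beyond the scatter), both beyond the scatter.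

Compound 4 `CC(C)(C)CCc1cnc(CCc2ccc(-c3ccccc3C(=O)O)cc2)[nH]1` differs from compound 3 in one place: 3,3-dimethylbutyl in place of phenyl on an aromatic carbon. Among the compounds with values here, no measured step covers a chain entering at this carbon. The steps that come closest are those into compound 3, in which a group held on a saturated chain carbon gave way to a ring bound directly to the five-membered ring, and the numbers rose strongly, as in a 110-fold higher number from compound 1 to compound 3 (2.04 log units; beyond the scatter) and a 17-fold higher number from compound 2 to compound 3 (1.24 log units; beyond the scatter). The entering 3,3-dimethylbutyl again puts a saturated chain on that carbon, but without a ring at its end, so the measured steps bear on it only loosely.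

With wide uncertainty the step is estimated as a 3.5-fold lower number from compound 3 to compound 4 (0.54 log units; beyond the scatter), a modest move towards a lower number. Compound 4 is therefore estimated in this assay at 250 nM, with a range from 40 nM to 1500 nM.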

Compound 4, half-maximal effective concentration: 6.2 nM
Beside the measured number, compound 4's estimate is 40-fold (1.61 log units) above it; the whole stated range lies above it.
By their numbers in this assay, from the lowest: compounds 4 and 1 (each within the scatter of the next); then compound 2; then compound 3.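

In this assay, a direct ring on this aromatic carbon, next to the ring nitrogen, proves unnecessary, as the ring-free 3,3-dimethylbutyl gives a 140-fold lower number from compound 3 to compound 4 (2.15 log units; beyond the scatter), although both groups have 6 heavy atoms. The comparisons with the two fluorinated compounds show that a ring at the end of the chain is not needed either: neopentyl in place of 4-fluorophenyl gives an 8.1-fold lower number from compound 2 to compound 4 (0.91 log units; beyond the scatter), while neopentyl in place of 3-fluorophenyl gives a 1.3-fold lower number from compound 1 to compound 4 (0.11 log units; within the scatter), a difference within the scatter, so the ring-free chain does as well as the better of the two fluorinated groups. No supporting data are available to explain why these changes have these effects.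

On these data alone, it remains open whether the branched end of the 3,3-dimethylbutyl matters, or whether an unbranched chain, a longer chain or a shorter isobutyl group would serve equally well on this carbon. It is also unknown how an ether oxygen or an amine within the chain would affect the number in this assay, or whether a cyclohexyl group would behave like the chain or like the phenyl.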